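Chromone Ester in Place of Biphenyl on the Piperidine Core

A few compounds are considered here, and "the series" means these few. Any claim that something is new, unique, unknown or untested is made for them only; others in the source may bear on it.

Compound 2 `COc1ccc(OCCCCCN2CCCC(COC(=O)c3ccccc3-c3ccccc3)C2)cc1` was tested in an in vitro functional assay on HEK ts201 cells for antagonist activity at Neuronal acetylcholine receptor; alpha4/beta2 (Homo sapiens), read by fluorescence and calcium flux; a higher number here means a weaker inhibitor, a lower number a stronger inhibitor; compound 2 gives 14500 nM. Among the measured compounds shown here, the only other measured compound, compound 1 `COc1ccc(OCCCCCN2CCCC(COC(=O)c3coc4ccccc4c3=O)C2)cc1`, gives 10000 nM in this assay, and the two values sit within the scatter of each other, as the step of a 1.5-fold higher number from compound 1 to compound 2 (0.16 log units; within the scatter) shows. Compound 3 `COc1ccc(OCCCCCN2CCCC(COC(=O)c3cc(=O)c4ccccc4o3)C2)cc1` differs from compound 2 in that (a group of 11 heavy atoms (9 carbon, 2 oxygen; one six-membered aromatic ring of carbon only, one six-membered aromatic ring with 1 hetero atom) in place of a group of 12 heavy atoms (12 carbon; 2 six-membered aromatic rings of carbon only), on a carbonyl carbon). This change mirrors the measured step of a 1.5-fold higher number from compound 1 to compound 2 (0.16 log units; within the scatter), which exchanged groups of the same kinds and barely moved the number, so no shift beyond the scatter is expected in this assay. Compound 3 is therefore estimated at 10000 nM, with a range of 4000 nM to 25000 nM. This is expected to amount to a 1.5-fold lower number from compound 2 to compound 3 (0.16 log units; within the scatter).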

Compound 3, half-maximal inhibitory concentration: 10200 nM
Compound 3: middle estimate off by 1.0-fold (0.01 log units), on the low side; low and high end bracket the measured number.
By their numbers in this assay, from the lowest: compounds 1, 3 and 2 (each within the scatter of the next).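

In this assay, replacing 2-phenylphenyl on this carbonyl carbon with the two-ring, oxygen-bearing group again leaves the number within the scatter, with a 1.4-fold lower number from compound 2 to compound 3 (0.15 log units; within the scatter). New here is that two groups with the same atom and ring counts but different arrangements cannot be told apart, with a 1.0-fold higher number from compound 1 to compound 3 (0.01 log units; within the scatter). No measurement is available to explain this flat result.

Going by these compounds, all three compounds sit within the scatter of one another, so it remains open whether an amine or a carboxylic acid on the group at this carbonyl carbon would move the number.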